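Anilines on a Shared Core: Methoxy Tried in Place of Iodo

A few compounds are considered here, and "the series" means these few. Any claim that something is new, unique, unknown or untested is made for them only; others in the source may bear on it.

compound 1, `Cc1n[nH]c2ccc(-c3nc4cnc(N5CCN(C)CC5)cn4c3Nc3cccc(F)c3)cc12`: 18.5%
compound 2, `Cc1n[nH]c2ccc(-c3nc4cnc(N5CCN(C)CC5)cn4c3Nc3cccc(Cl)c3)cc12`: 0%
compound 3, `Cc1n[nH]c2ccc(-c3nc4cnc(N5CCN(C)CC5)cn4c3Nc3ccc(I)cc3)cc12`: 0%

In a functional assay on MV4-11 cells (Homo sapiens) for inhibition, with a stated time of 120 h, tested at 10 uM (on this read-out higher numbers stand for more inhibition at the one concentration tested (going by the name of the read-out) and lower numbers for less inhibition), compound 3 gives 0%, level with compound 2 at the digits shown, as no change at the digits printed from compound 2 to compound 3 (within the scatter) confirms. Compound 1 stands apart, the difference being a number 18.5 percentage points lower from compound 1 to compound 3 (beyond the scatter). Compound 4, `COc1ccc(Nc2c(-c3ccc4[nH]nc(C)c4c3)nc3cnc(N4CCN(C)CC4)cn23)cc1`, differs from compound 3 by methoxy in place of iodo on an aromatic carbon. For the measured compounds named here, no measured step trades iodo for methoxy, so only indirect guidance exists: a number 18.5 percentage points lower from compound 1 to compound 2 (beyond the scatter) and a number 18.5 percentage points lower from compound 1 to compound 3 (beyond the scatter) show modest movement when the aniline substituent changes, while no change at the digits printed from compound 2 to compound 3 (within the scatter) shows none. Compound 4 is therefore expected to remain close to compound 3, with a number 5 percentage points higher from compound 3 to compound 4 (within the scatter) within the scatter. The estimate for compound 4 is 5%, expected between 0% and 25%.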

Compound 4, a percentage reported as inhibition, at one concentration (the size of the read-out at that concentration, not a potency): 3.32%
For compound 4 the middle estimate is 1.7 percentage points above the measured one; low and high end bracket the measured number.
By their numbers in this assay, from the lowest: compounds 2, 3 and 4 (each within the scatter of the next); then compound 1.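

In this assay, methoxy on this aromatic carbon, para to a large group, reads much as iodo does, with a number 3.3 percentage points higher from compound 3 to compound 4 (within the scatter) and so no visible effect from the added hydrogen-bond acceptor. The 4-methoxyphenyl group likewise shows a number 3.3 percentage points higher from compound 2 to compound 4 (within the scatter) against the 3-chlorophenyl group, yet a number 15.2 percentage points lower from compound 1 to compound 4 (beyond the scatter) leaves the 3-fluorophenyl group of compound 1 apart from it. Nothing at hand explains any of these steps. Still open, as far as these compounds go, is whether an amine or a carboxylic acid on this same carbon would read differently from iodo and methoxy, and whether a longer chain than methoxy would change the number.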